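The source may hold more compounds than are shown below. What is called first, only, known or untested is meant among the compounds shown, and "the series" means these compounds.

Measured so far in an assay on cells for inhibition of S-adenosylmethionine decarboxylase proenzyme (Homo sapiens), read by mass spectrometry, at pH 7.2; on this read-out lower numbers stand for stronger inhibition and higher numbers for weaker inhibition:

Compound 1, `Cc1cc(Nc2cccc(Cl)c2)nc(N)n1`, gives > 180000 nM.
Compound 2, `Cc1cc(Nc2cccc(Cl)c2Cl)nc(N)n1`, gives > 180000 nM.
Compound 3, `Cc1cc(Nc2ccccc2C)nc(N)n1`, gives > 180000 nM.

Each of these three readings is a limit of the assay rather than a number: all three sit at the limit of > 180000 nM in this assay, at which 3 of the 3 values shown sit. Compound 1 and compound 2 share a core and differ in one place, (chloro in place of hydrogen on an aromatic carbon). The step between them, a step that the two limits leave unreadable from compound 1 to compound 2, cannot be sized, since both ends are limits. The difference between the core of compound 3 and the core of compound 1 is not broken down here.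

Compound 4, `Cc1cc(Nc2ccc(Cl)cc2C)nc(N)n1`, is not yet measured. It differs from compound 3 by chloro in place of hydrogen on an aromatic carbon. This is the same kind of change as that from compound 1 to compound 2, though the surroundings differ: there the entering chloro was ortho to a chloro group and ortho to a group of 9 heavy atoms; here it is meta to a methyl group and para to a group of 9 heavy atoms.

Because compound 3 gives only the limit > 180000 nM, and because the measured step that the two limits leave unreadable from compound 1 to compound 2 reveals nothing readable, the expected step that the limit leaves unreadable from compound 3 to compound 4 rests on little. Compound 4 is expected to give about 300000 nM in this assay, estimated between 90000 nM and 1000000 nM, most likely again reported only as a limit.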

Compound 4, half-maximal inhibitory concentration: > 180000 nM
Compound 4: no number, only a limit (the forecaster's own chance of this, stated with the estimate: 85%); the middle value is on the limit's open side.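

In going from compound 3 to compound 4, no step can be read, as both results are limits of the assay and not numbers: the limit of > 180000 nM in this assay, at which 4 of the 4 values shown sit. The compounds shown leave open how strongly any of them inhibits in this assay, and whether chloro in place of hydrogen on an aromatic carbon changes that at all.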